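This account rests on a few compounds, and the source may have more. Where it says the series, first, only, none or still open, it means among the compounds named here.

Compound 1 `CCCCNc1nc(N)nc2c1CNCC2` was tested in an assay on HEK293 cells for agonist activity at Toll-like receptor 8 (Homo sapiens), read by a luciferase reporter, with a stated time of 6 h (on this read-out higher numbers stand for an effect only at larger amounts of compound and lower numbers for an effect already at smaller amounts), where compound 1 gives 7.2 uM. Among the three measured values this is the highest. Compound 2 `CCCCNc1nc(N)nc2c1CCN(C)C2`, which carries a methyl on an amine nitrogen in its ring, gives 0.2 uM in this assay, and compound 3 `CCCCNc1nc(N)nc2c1CCN(S(C)(=O)=O)C2`, which carries a methylsulfonyl on that nitrogen, gives 0.8 uM. Both of these values lie well below that of compound 1, further apart than the usual scatter. Among the measured compounds shown here, the one measured step, a 4.0-fold higher number from compound 2 to compound 3 (0.60 log units; beyond the scatter), shows that exchanging one group on the ring nitrogen for another shifts the number, but only modestly compared with the gap that separates both substituted compounds from compound 1.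

Compound 4 `CCCCNc1nc(N)nc2c1CN(Cc1ccco1)CC2` differs from compound 1 in one place: (furan-2-yl)methyl in place of hydrogen on an amine nitrogen in a ring. For the measured compounds named here, no measured pair makes exactly this change, so the expectation rests on the observation that compound 2 and compound 3, each bearing a group on a ring amine nitrogen, give lower numbers than compound 1. A lower number is therefore expected for compound 4, a step of roughly a 7.2-fold lower number from compound 1 to compound 4 (0.86 log units; beyond the scatter) in this assay. Compound 4 is estimated to give about 1 uM, likely between 0.2 uM and 5 uM.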

Compound 4, minimum effective concentration: 0.08 uM
For compound 4 the middle estimate is 13-fold (1.10 log units) above the measured one; the measured number lies below the stated range.
By their numbers in this assay, from the lowest: compound 4; then compound 2; then compound 3; then compound 1.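

Placing (furan-2-yl)methyl in place of hydrogen on the amine nitrogen in the ring gives a 90-fold lower number from compound 1 to compound 4 (1.95 log units; beyond the scatter) in this assay, so this position of the core of compound 1 accepts a group with a five-membered aromatic ring and the number falls a long way. Among the compounds shown here, this is the first measured step that starts from a free hydrogen on a ring nitrogen, whereas the earlier step, a 4.0-fold higher number from compound 2 to compound 3 (0.60 log units; beyond the scatter), exchanged one group for another on a core that differs from that of compound 1 and so cannot be set directly beside the new one. Nothing at hand explains why the step is so large.

As far as these compounds go, a single substituent cannot separate the effect of the furan ring from that of simply replacing the hydrogen with a carbon group, so it remains open whether a plain methyl, a benzyl or a longer alkyl chain on this same nitrogen would give a similar step. Compound 4 also differs from compound 2 and compound 3 in more than one place, which leaves open how the position of the ring nitrogen itself affects the number.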